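Chloro for methyl on the amide aryl ring

The source may report more compounds than this note shows. Statements on the series, on what has been measured and on what is new or still open speak of the compounds shown alone.

Compound 1 `Cc1ccc(NC(=O)c2cccc(C(F)(F)F)c2)cc1C#Cc1nn(C[C@@H](C)CO)c2ncnc(N)c12` gives 9500 nM in an ADME assay on HepG2 cells (Homo sapiens) for antiproliferative activity, read by MTT assay, with a stated time of 72 h; a lower number here means a stronger inhibitor, a higher number a weaker inhibitor. Compound 3 `Cc1ccc(NC(=O)c2ccc(C)c(C(F)(F)F)c2)cc1C#Cc1nn(C[C@@H](C)CO)c2ncnc(N)c12` gives 8300 nM in this assay, and the move between them is a 1.1-fold lower number from compound 1 to compound 3 (0.06 log units; within the scatter). Compound 2 `Cc1ccc(NC(=O)c2cnc(C(C)(C)C)s2)cc1C#Cc1nn(C[C@@H](C)CO)c2ncnc(N)c12` gives > 10000 nM in this assay, a limit rather than a number. That value is the limit of > 10000 nM in this assay, at which 1 of the 3 values shown sits. The two ring swaps read an at least 1.0-fold higher number from compound 1 to compound 2 (0.02 log units; that floor lies within the scatter) and an at least 1.2-fold lower number from compound 2 to compound 3 (0.08 log units; that floor lies within the scatter). Compound 3 thus sits together with compound 1 at a number near the limit, and nothing among the three compounds separates from the scatter.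

Compound 4 `Cc1ccc(NC(=O)c2ccc(Cl)c(C(F)(F)F)c2)cc1C#Cc1nn(C[C@@H](C)CO)c2ncnc(N)c12` differs from compound 3 by chloro in place of methyl on an aromatic carbon. Within the data shown here, no measured step swaps chloro for methyl. The closest in place is the methyl-for-hydrogen step, a 1.1-fold lower number from compound 1 to compound 3 (0.06 log units; within the scatter), which stayed within the scatter, and the ring swaps through compound 2 likewise stayed within the scatter or at the limit. The expectation for compound 4 is therefore a step of a 1.0-fold lower number from compound 3 to compound 4 (0.02 log units; within the scatter) in this assay, not beyond the scatter. The estimate for compound 4 in this assay is 8000 nM, with a range of 4000 nM to 16000 nM, and a fair chance that only a limit is returned.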

Compound 4, half-maximal inhibitory concentration: > 10000 nM
Compound 4: only a limit was reported (the forecaster's own chance of this, stated with the estimate: 30%); middle value at least 1.2-fold (0.09 log units) away from the limit.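

In this assay compound 4 returns only a limit, > 10000 nM, and not a number. On these data alone, at this position, ortho to a trifluoromethyl group and para to a large group, the change of methyl to chloro reads as an at least 1.2-fold higher number from compound 3 to compound 4 (0.08 log units; that floor lies within the scatter), and the change of hydrogen to chloro reads as an at least 1.0-fold higher number from compound 1 to compound 4 (0.02 log units; that floor lies within the scatter); both floors lie within the scatter, so this position has not yet given a step that separates from it, and the true size of either step remains unknown. What is new is that a change on this ring, and not only a swap of the whole ring, can move a compound from a number to the limit, and compound 2 and compound 4 both standing there means the step between them cannot be read: the limit of > 10000 nM in this assay, at which 2 of the 4 values shown sit.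

As far as these compounds go, how far compound 4 lies past the limit stays open, so chloro cannot yet be ranked against methyl or hydrogen at this position. Also open, from the compounds shown here alone, is whether an amine, a methoxy group or a carboxylic acid at the same position would give a number clearly separated from those of compound 1 and compound 3.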